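A few compounds are considered here, and "the series" means these few. Any claim that something is new, unique, unknown or untested is made for them only; others in the source may bear on it.

Working notes on the series.

Three compounds in this set have been run in a functional assay on the whole organism with Rattus norvegicus as the target, at a dose of 100 mg/kg; on this read-out lower numbers stand for less inhibition and higher numbers for more inhibition at the one dose given (going by the name of the read-out). Compound 1 `CC/N=C(/NC#N)NCCCn1nc(-c2ccccc2)cc(C)c1=O` gives 23.5%. Compound 2 `N#CNC(=N)NCCCCCn1nc(-c2ccccc2)ccc1=O` gives 31%. Compound 3 `C/N=C(\S)NCCCCCn1nc(-c2ccccc2)ccc1=O` gives 68.9%, the highest of the three numbers: compound 2 sits nearest, compound 1 furthest, and both gaps lie beyond the scatter.

One step between measured compounds is defined by a single change. It runs a number 37.9 percentage points higher from compound 2 to compound 3 (beyond the scatter).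

Compound 4 `CC/N=C(/NC#N)NCCCn1nc(-c2ccccc2)ccc1=O` is not yet measured. It differs from compound 3 as follows: a group of 8 heavy atoms (4 carbon, 4 nitrogen; no ring) in place of a group of 7 heavy atoms (4 carbon, 2 nitrogen, 1 sulfur; no ring), on a saturated chain carbon, three bonds along the chain from an aromatic nitrogen. Going by the values given here, the measured step from compound 2 to compound 3 bears on this change in reverse sense, since the group that enters in compound 4 is of the same family as the one that left compound 2, while the group that leaves compound 4 is of the same family as the one that entered compound 3. That step was large. Compound 1, which carries the entering group on the core of compound 1, stands low in this assay, and compound 2 stands low as well.

The expectation is therefore a large fall, a number 41.9 percentage points lower from compound 3 to compound 4 (beyond the scatter), in this assay. Compound 4 is estimated at 27%, with a range from 12% to 42%.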

Compound 4, a percentage reported as inhibition, in the whole organism at one dose (the size of the read-out at that dose, not a potency): 62.9%
Compound 4: the middle estimate sits 35.9 percentage points below what was measured; the whole stated range lies below it.
By their numbers in this assay, from the lowest: compounds 1 and 2 (each within the scatter of the next); then compounds 4 and 3 (each within the scatter of the next).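

In this assay, the exchange on a saturated chain carbon, three bonds along the chain from an aromatic nitrogen, gives a number 6 percentage points lower from compound 3 to compound 4 (within the scatter), so the sulfur-bearing group and the group with 4 carbon and 4 nitrogen atoms cannot be told apart at this dose on this shared core. The entering family therefore does not go with a low number in every setting: the exchange between two groups of equal heavy-atom count at the same place gives a number 31.9 percentage points higher from compound 2 to compound 4 (beyond the scatter), which shows that the arrangement of the group and its chain counts, and not merely the family. Hydrogen in place of methyl on an aromatic carbon gives a number 39.4 percentage points higher from compound 1 to compound 4 (beyond the scatter), the first sign that a change away from the chain can move this read-out by a large margin, at least for this one pair.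

No measurement offered here accounts for either large step. From the compounds shown here alone, how an amine or a carboxylic acid would read in place of the chain-end group, and whether ethyl or chlorine on that aromatic carbon would behave as methyl does, stays open.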